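Cyano for Bromo: Projecting the Next Analogue's Potency

The compounds below may be only part of what the source reports. "The series", "measured", "known", "first", "only" and "open" are said of these compounds alone.

Two compounds share a core and differ at a single aromatic carbon. Compound 1 `NS(=O)(=O)CC(=O)NCCSc1nonc1/C(=N/O)Nc1cccc(C(F)F)c1` carries a difluoromethyl group there, and in an assay for inhibition of Indoleamine 2,3-dioxygenase 1 (Homo sapiens), read by fluorescence, with a stated time of 24 h (a lower number here means a stronger inhibitor, a higher number a weaker inhibitor), compound 1 gives 17 nM. Compound 2 `NS(=O)(=O)CC(=O)NCCSc1nonc1/C(=N/O)Nc1cccc(Br)c1` carries bromo at that carbon, and in this assay compound 2 gives 8.1 nM. Within the data shown here, that exchange produced a 2.1-fold lower number from compound 1 to compound 2 (0.32 log units; beyond the scatter), so compound 2 stands as the lower of the two numbers measured so far. Compound 3 `N#Cc1cccc(N/C(=N\O)c2nonc2SCCNC(=O)CS(N)(=O)=O)c1` is the next analogue: cyano in place of bromo on an aromatic carbon. Among the measured compounds shown here, no measured step exchanges bromo for cyano. For the measured compounds named here, the only step available, a 2.1-fold lower number from compound 1 to compound 2 (0.32 log units; beyond the scatter), concerns a different pair of groups at the same carbon and shows that one substituent swap there moved the number only modestly. Compound 3 is therefore expected to show a 1.5-fold higher number from compound 2 to compound 3 (0.17 log units; within the scatter), a shift that may not exceed the scatter. Compound 3 is estimated at 12 nM, within a range from 4 nM to 35 nM.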

Compound 3, half-maximal inhibitory concentration: 44 nM
Beside the measured number, compound 3's estimate is 3.7-fold (0.56 log units) below it; measured number outside the range, above it.
By their numbers in this assay, from the lowest: compound 2; then compound 1; then compound 3.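

The exchange of bromo for cyano at this aromatic carbon gives a 5.4-fold higher number from compound 2 to compound 3 (0.73 log units; beyond the scatter) in this assay, so this carbon does not tolerate every swap equally. Cyano also falls behind difluoromethyl, with a 2.6-fold higher number from compound 1 to compound 3 (0.41 log units; beyond the scatter), which places the three groups in a single order, bromo, then difluoromethyl, then cyano, with every step between them beyond the scatter. Cyano brings one hydrogen-bond acceptor and one more heavy atom than bromo, but no measurement given here bears on why the number rose.

The compounds shown leave open where other groups at this carbon, such as chloro, methoxy or an amine, would fall in this order. They also leave open whether the same order would hold with a longer chain in place of the one in the shared core.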